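Adding methoxy to the phenyl group on the shared core

This account rests on a few compounds, and the source may have more. Where it says the series, first, only, none or still open, it means among the compounds named here.

In a functional assay on A549 cells (Homo sapiens) for inhibition, read by MTT assay, with a stated time of 48 h (on this read-out higher numbers stand for weaker inhibition and lower numbers for stronger inhibition), compound 1 `CCOC(=O)c1cc(-c2ccccc2)nn1CC(O)COc1ccc(Cl)cc1` gives 59000 nM, and compound 2 `CCOC(=O)c1cc(-c2ccccc2)nn1CC(O)COc1ccccc1OC` gives 58000 nM; the two numbers sit within the usual scatter of each other, so neither can be called the stronger inhibitor. For the measured compounds named here, the only measured step, a 1.0-fold lower number from compound 1 to compound 2 (0.01 log units; within the scatter), altered the aryl group attached to the oxygen on the saturated carbon and left the phenyl on the core untouched. Compound 3 `CCOC(=O)c1cc(-c2ccc(OC)cc2)nn1CC(O)COc1ccccc1OC` differs from compound 2 at that phenyl: methoxy in place of hydrogen on an aromatic carbon. Going by the values given here, no measured step touches this position, so nothing in the data points one way or the other. Among the compounds with values here, with the single measured change having produced no shift beyond the scatter, the expectation for compound 3 is a step of a 1.1-fold lower number from compound 2 to compound 3 (0.02 log units; within the scatter) in this assay, that is, none beyond the scatter. Compound 3 is therefore expected to give about 55000 nM, within a range from 25000 nM to 120000 nM.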

Compound 3, half-maximal inhibitory concentration: 68000 nM
The estimate for compound 3 lay 1.2-fold (0.09 log units) below the measured number, and the stated range covers the measured number.
By their numbers in this assay, from the lowest: compounds 2, 1 and 3 (each within the scatter of the next).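

For the compounds shown here, the phenyl group on the shared core changes here for the first time, and in this assay replacing phenyl with 4-methoxyphenyl gives a 1.2-fold higher number from compound 2 to compound 3 (0.07 log units; within the scatter) in this series. A methoxy on this aromatic carbon, para to a large group, therefore produces no change that can be separated from the normal variation between repeated measurements. That matches the earlier swap of the aryl group on the oxygen, which gave a 1.0-fold lower number from compound 1 to compound 2 (0.01 log units; within the scatter), so neither of the two changes shown moves the number beyond the scatter, and nothing measured here offers an explanation for this result.

From the compounds shown here alone, it remains open whether an amine or a carboxylic acid at this position, or a longer chain in place of methoxy, would shift the number. The ester and the hydroxyl stay the same in all three compounds, so their contribution cannot be read from these data.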